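Swapping Iodo for Chloro on the Aryl Ring

A few compounds are considered here, and "the series" means these few. Any claim that something is new, unique, unknown or untested is made for them only; others in the source may bear on it.

Three compounds have so far been tested in a functional assay on NIH3T3 cells (Mus musculus) for antiproliferative activity; a higher number here means a weaker inhibitor, a lower number a stronger inhibitor:

Compound 1, `Cc1nc2c([nH]1)C(=O)/C(=N/c1ccc(I)cc1)C(Cl)=C2O`, gives 600 nM.
Compound 2, `Cc1nc2c([nH]1)C(=O)/C(=N/c1cccc(Cl)c1Cl)C(Cl)=C2O`, gives 2300 nM.
Compound 3, `Cc1nc2c([nH]1)C(=O)/C(=N/c1ccc(F)c(F)c1F)C(Cl)=C2O`, gives 1600 nM.

Compound 1 has the lowest number of the three, and so is the strongest inhibitor in this set. Its distance to compound 3 is the smaller one, its distance to compound 2 the larger one, and both lie beyond the usual scatter of repeated measurements. No two of these compounds differ in only one place, so none of them offers a single-change step to lean on.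

Compound 4, `Cc1nc2c([nH]1)C(=O)/C(=N/c1ccc(Cl)cc1)C(Cl)=C2O`, has not yet been measured. Relative to compound 1 it differs in one respect: chloro in place of iodo on an aromatic carbon. Everything else in the molecule is kept.

With no comparable single-atom exchange among the measured compounds, the expected step is modest. From compound 1 the step is estimated to be a 1.7-fold higher number from compound 1 to compound 4 (0.22 log units; within the scatter), toward a somewhat weaker inhibitor but close to the edge of the scatter. Compound 4 is therefore expected to give about 1000 nM, within a range from 400 nM to 2500 nM.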

Compound 4, half-maximal inhibitory concentration: 1300 nM
Compound 4: middle estimate off by 1.3-fold (0.11 log units), on the low side, and the stated range covers the measured number.
By their numbers in this assay, from the lowest: compound 1; then compounds 4, 3 and 2 (each within the scatter of the next).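

Within the data shown here, the exchange of 4-iodophenyl for 4-chlorophenyl gives the first single-change step in this set: in this assay, it gives a 2.2-fold higher number from compound 1 to compound 4 (0.34 log units; beyond the scatter). The atom on this aromatic carbon therefore matters, since replacing iodo with chloro moves the number beyond the scatter toward a weaker inhibitor, although the step is modest and the rest of the molecule is kept. Nothing shown here explains why this exchange has that effect.

Where bromo, a methoxy group or an amine on this same aromatic carbon would land remains open, as does the result of having only hydrogen there. Compounds 2 and 3 differ from compound 1 and compound 4 in more than one place, so they cannot show what any single halogen contributes.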